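Moving the chlorine on a triazole benzyl group

The compounds below may be only part of what the source reports. "The series", "measured", "known", "first", "only" and "open" are said of these compounds alone.

For the measured compounds named here, compound 1 `O=C(OCc1ccccc1)N1CCN(C(=S)SCc2cn(Cc3ccc(Cl)cc3)nn2)CC1` is the only compound of this set with a number. In a functional assay on MCF7 cells (Homo sapiens) for inhibition, read by MTT assay, with a stated time of 72 h (a lower number here means a stronger inhibitor, a higher number a weaker inhibitor), compound 1 gives 27500 nM, a weak result on this scale. Compound 2 `S=C(SCc1cn(Cc2ccc(Cl)cc2)nn1)N1CCNCC1` lacks the benzyl carbamate of compound 1. In this assay compound 2 has "not determined" (no result reported), so nothing can be said of its strength.

Compound 3 `O=C(OCc1ccccc1)N1CCN(C(=S)SCc2cn(Cc3ccccc3Cl)nn2)CC1` has the same atoms as compound 1, joined differently: the change is 2-chlorophenyl in place of 4-chlorophenyl on a saturated chain carbon bound to an aromatic nitrogen. Cut one bond further out, the same difference reads 4-chlorobenzyl to 2-chlorobenzyl.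

Going by the values given here, no measured pair shows what such a shift of the chlorine does here, so the expectation rests on compound 1 alone. A change of this kind is expected to stay small, no larger than the scatter, in either direction, giving an expected step of a 1.1-fold lower number from compound 1 to compound 3 (0.04 log units; within the scatter). Compound 3 is therefore estimated at 25000 nM in this assay, with a range from 8000 nM to 80000 nM.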

Compound 3, half-maximal inhibitory concentration: 21400 nM
Estimate against measurement, compound 3: 1.2-fold (0.07 log units) above; the range from low to high includes it.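

For the compounds shown here, this is the first measured look at the chlorine on this benzyl group: in this assay, 2-chlorophenyl in place of 4-chlorophenyl on a saturated chain carbon bound to an aromatic nitrogen gives a 1.3-fold lower number from compound 1 to compound 3 (0.11 log units; within the scatter) and stays within the scatter. Compound 1 and compound 3 therefore cannot be told apart here, and moving the chlorine in this one pair leaves no visible mark on the read-out. Nothing further is at hand that bears on this result.

Still open, as far as these compounds go, is whether the chlorine itself counts for anything, which a plain phenyl, or a methoxy group or an amine in the chlorine's place, would help to show. The shift also rests on a single pair, so it says nothing about how the same move behaves on another part of the shared core.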